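The source may hold more compounds than are shown below. What is called first, only, known or untested is meant among the compounds shown, and "the series" means these compounds.

Three compounds sharing a peracetylated sugar linked through a triazole to an aromatic fragment have been tested in a functional assay on DU-145 cells (Homo sapiens) for cytotoxicity, read by sulforhodamine B assay, with a stated time of 48 h; a higher number here means a weaker inhibitor, a lower number a stronger inhibitor. Compound 1, `COc1ccc2c(c1)c(/C=N/O)cn2Cc1cn([C@@H]2O[C@H](COC(C)=O)[C@@H](OC(C)=O)[C@H](OC(C)=O)[C@H]2OC(C)=O)nn1`, gives 88400 nM in this assay. Compound 2, `CC(=O)OC[C@H]1O[C@@H](n2cc(Cn3cc([N+](=O)[O-])c4ccccc43)nn2)[C@H](OC(C)=O)[C@@H](OC(C)=O)[C@@H]1OC(C)=O`, gives 60900 nM in this assay. Compound 3, `CC(=O)OC[C@H]1O[C@@H](n2cc(CN3C(=O)/C(=C\c4ccc(C)cc4)c4ccccc43)nn2)[C@H](OC(C)=O)[C@@H](OC(C)=O)[C@@H]1OC(C)=O`, gives 9400 nM in this assay, the lowest of the three numbers; its gap to compound 2 and its larger gap to compound 1 both lie beyond the usual scatter of repeated measurements, so compound 3 is the strongest inhibitor of the three.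

The step to compound 4, `CC(=O)OC[C@H]1O[C@@H](n2cc(CN3C(=O)/C(=C\c4ccco4)c4ccccc43)nn2)[C@H](OC(C)=O)[C@@H](OC(C)=O)[C@@H]1OC(C)=O`, changes only the aromatic substituent on the exocyclic double bond: furan-2-yl in place of 4-methylphenyl on a double-bonded chain carbon bound to a double-bonded ring carbon. Among the measured compounds shown here, no measured pair among the three compounds shows a change of this kind, so there is no directly comparable step to lean on. The scaffold carrying the exocyclic double bond is kept intact, and the exchange of one aromatic ring for another at the same place is expected to move the number only modestly, if at all, with a slight lean toward a weaker inhibitor; the step from compound 3 to compound 4 is estimated as a 1.4-fold higher number from compound 3 to compound 4 (0.14 log units; within the scatter). Compound 4 is therefore expected to give about 13000 nM in this assay, with a likely range from 4500 nM to 38000 nM.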

Compound 4, half-maximal inhibitory concentration: 16900 nM
The estimate for compound 4 lay 1.3-fold (0.11 log units) below the measured number, within the range that was stated.
By their numbers in this assay, from the lowest: compounds 3 and 4 (each within the scatter of the next); then compounds 2 and 1 (each within the scatter of the next).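

In this assay, among the compounds shown here, the exchange of 4-methylphenyl for furan-2-yl on a double-bonded chain carbon bound to a double-bonded ring carbon gives a 1.8-fold higher number from compound 3 to compound 4 (0.25 log units; within the scatter) and is the first step that differs in one place. It shows that, at this position, a five-membered aromatic ring with 1 hetero atom and a six-membered aromatic ring of carbon only cannot be told apart in this read-out, even though the entering group has fewer heavy atoms and adds a hydrogen-bond acceptor. Nothing available here accounts for this result or links it to any property of either group.

The compounds shown leave open how the number responds when a group other than an aromatic ring stands at this place, such as an amine, a carboxylic acid or a longer alkyl chain. They also leave open whether the same exchange gives a comparable step when free hydroxyl groups replace the acetate esters on the sugar, or when the aromatic ring carries a fluorine or a methoxy group.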